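Furan-3-yl in place of isopropyl on the shared core

The source may report more compounds than this note shows. Statements on the series, on what has been measured and on what is new or still open speak of the compounds shown alone.

Of the compounds shown here, three have been read so far in a functional assay on CUTLL1 cells (Homo sapiens) for inhibition, read by resazurin assay, with a stated time of 48 h, in the absence of a further agent; a lower number here means that less compound is needed, a higher number that more compound is needed for the effect. Compound 1 `Nc1ncc(-c2ccc(F)cc2)c(C2CC2)n1` gives > 100000 nM, which is a limit and not a number. Compound 3 `CC(C)c1nc(N)ncc1-c1ccncc1` gives > 100000 nM, which is likewise a limit and not a number. Most of the picture so far is therefore (the limit of > 100000 nM in this assay, at which 2 of the 3 values shown sit). Among the compounds with values here, compound 2 `C=Cc1cnccc1-c1cnc(N)nc1C1CC1` is the only member with a number, at 30000 nM.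

Within the data shown here, compound 3 thus offers no measured number to step from, only its limit. Compound 4 `Nc1ncc(-c2ccncc2)c(-c2ccoc2)n1` carries furan-3-yl in place of isopropyl on an aromatic carbon, next to the ring nitrogen: furan-3-yl in place of isopropyl on an aromatic carbon. Among the measured compounds shown here, no measured step sizes this change, so any expectation rests on thin ground. The expected move in this assay is modest and towards less compound needed, with an estimated at least 2.0-fold lower number from compound 3 to compound 4 (0.30 log units; that floor lies within the scatter). The only numerical anchor for that expectation is compound 2 at 30000 nM. A further reading that returns only a limit remains quite possible, as happened with compound 1 and compound 3. For compound 4 the expected value is 50000 nM, with an estimated range from 15000 nM to 100000 nM.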

Compound 4, half-maximal effective concentration: > 100000 nM
Compound 4: only a limit was reported; the forecaster's own chance of this, stated with the estimate: 45%; middle value at least 2.0-fold (0.30 log units) away from the limit.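

In this assay compound 4 gives > 100000 nM, which is a limit and not a number. Compound 3 also carries only a limit, so the step between compound 3 and compound 4 cannot be read. The compounds shown leave open whether furan-3-yl in place of isopropyl changes the read-out at all, and most values sit at one limit: the limit of > 100000 nM in this assay, at which 3 of the 4 values shown sit.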